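The compounds below may be only part of what the source reports. "The series", "measured", "known", "first", "only" and "open" are said of these compounds alone.

Of the compounds shown here, two sharing one core have been measured so far in an ADME assay on RAW264.7 cells (Mus musculus) for cytotoxicity, read by MTT assay, with a stated time of 24 h; on this read-out lower numbers stand for higher toxicity in this test and higher numbers for lower toxicity in this test. Compound 1 (`CC/C=C\C[C@H]1C(=O)C=C[C@H]1CC(=O)OCC`) gives 146 uM. Compound 2 (`CC/C=C\C[C@H]1C(=O)C=C[C@H]1CC(=O)OCCC`) gives 35 uM, the lower of the two numbers, so it is the more toxic of this pair in this assay.

Compound 3 (`CC/C=C\C[C@H]1C(=O)C=C[C@H]1CC(=O)OCCCC`) lengthens the same chain once more, from propyl to butyl: methyl in place of hydrogen on a saturated chain carbon, three bonds along the chain from an oxygen next to a carbonyl group. Within the data shown here, only one measured step bears on this change. It is the same swap of methyl for hydrogen, made two bonds along the chain from an oxygen next to a carbonyl group, and it amounts to a 4.2-fold lower number from compound 1 to compound 2 (0.62 log units; beyond the scatter). That step lies beyond the usual scatter, but a single step cannot show whether a trend continues along the chain. The same direction is therefore expected, with a somewhat smaller size held as the cautious guess. The expected change is a 2.2-fold lower number from compound 2 to compound 3 (0.34 log units; beyond the scatter). For compound 3 the estimated value is 16 uM, with an expected range of 6 uM to 40 uM.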

Compound 3, half-maximal toxic concentration: 31 uM
For compound 3 the middle estimate is 1.9-fold (0.29 log units) below the measured one; the range from low to high includes it.
By their numbers in this assay, from the lowest: compounds 3 and 2 (each within the scatter of the next); then compound 1.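

The extra methyl, three bonds along the chain from an oxygen next to a carbonyl group, does not repeat the earlier step: in this assay there is a 1.1-fold lower number from compound 2 to compound 3 (0.05 log units; within the scatter), so the propyl and butyl compounds cannot be told apart here, whereas the same swap two bonds along gave a 4.2-fold lower number from compound 1 to compound 2 (0.62 log units; beyond the scatter). The longer chain still separates compound 3 from compound 1, with a 4.7-fold lower number from compound 1 to compound 3 (0.67 log units; beyond the scatter), so across these three compounds the gap opens on going to the propyl chain, and the further carbon adds nothing that can be distinguished from the scatter. Nothing shown here explains why the effect of lengthening the chain appears at one carbon and not at the next.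

Three compounds cannot show whether this is a true plateau or only a pause, and a longer chain such as pentyl or hexyl would be needed to tell the two apart. On these data alone, how the number would respond to something other than a plain carbon chain at this place, such as a branched isopropyl group or a chain ending in an amine or a carboxylic acid, also stays open.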